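A few compounds are considered here, and "the series" means these few. Any claim that something is new, unique, unknown or untested is made for them only; others in the source may bear on it.

In a functional assay on SK-OV-3 cells (Homo sapiens) for inhibition, read by ELISA, with a stated time of 24 h (a higher number here means a weaker inhibitor of growth, a lower number a stronger inhibitor of growth), only two results exist so far. Compound 1 (`CO/N=C/C=C/c1ccccc1OC(=O)c1ccccc1`) gives > 100000 nM, and this is a limit of the assay, not a number. Within the data shown here, compound 2 (`COc1ccccc1/C=C/C(=O)NO`) gives 48800 nM, the only true number available, so it cannot yet be placed on a scale of measured values.

Compound 3 (`O=C(/C=C/c1ccccc1O)NO`) keeps the structure of compound 2 except in one place: hydrogen in place of methyl on an oxygen on an aromatic ring. Hydrogen stands in place of methyl on an oxygen on an aromatic ring, so methoxy becomes hydroxy. Among the measured compounds shown here, no pair of measured compounds shows what this exchange does in this assay, which leaves the size of the step an open question. The best starting point is compound 2 at 48800 nM, and no step beyond the usual scatter of repeat measurements is expected, in either direction. The expected step is a 1.2-fold lower number from compound 2 to compound 3 (0.09 log units; within the scatter), and it should be read as a rough estimate. For compound 3 the estimated value is 40000 nM, with an expected range from 15000 nM to 100000 nM.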

Compound 3, concentration for 50% growth inhibition: 50400 nM
Estimate against measurement, compound 3: 1.3-fold (0.10 log units) below; measured number inside the range.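

Among these compounds, the first step that can be read in this assay is a 1.0-fold higher number from compound 2 to compound 3 (0.01 log units; within the scatter), and it comes from putting hydrogen in place of methyl on an oxygen on an aromatic ring. Among the compounds shown here, at this place, then, methoxy and hydroxy cannot be told apart in this assay: removing the methyl leaves the growth inhibition of compound 2 unchanged within the scatter, which no earlier pair could show. The scale still has only two true numbers, both from this one exchange, and it still has a known upper end that limits what can be read from further weak compounds: the limit of > 100000 nM in this assay, at which 1 of the 3 values shown sits.

As far as these compounds go, whether a larger group on this oxygen, such as an ethyl group or a longer chain, or an amine in place of the oxygen, would shift the number remains open. Also open, from the compounds shown here alone, is what a carboxylic acid would do in place of the hydroxamic acid shared by compound 2 and compound 3, and whether any single change can produce a step beyond the scatter.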